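Swapping the amide aryl group on a catechol diether core

The source may report more compounds than this note shows. Statements on the series, on what has been measured and on what is new or still open speak of the compounds shown alone.

Of the compounds shown here, three sharing one core have been measured in an assay on isolated protein for inhibition of phosphodiesterase 4A (Sus scrofa); a higher number here means a weaker inhibitor, a lower number a stronger inhibitor. Compound 1 `COc1ccc(C(=O)Nc2ccccc2F)cc1OC1CCCC1` gives 10700 nM. Compound 2 `COc1ccc(C(=O)Nc2c(F)cccc2F)cc1OC1CCCC1` gives 70 nM, and compound 3 `COc1ccc(C(=O)Nc2ccccc2O)cc1OC1CCCC1` gives 1300 nM. Compound 3 therefore stands second highest of the three numbers, nearer to compound 1 than to compound 2. The steps among them are large: a 150-fold lower number from compound 1 to compound 2 (2.18 log units; beyond the scatter), a 19-fold higher number from compound 2 to compound 3 (1.27 log units; beyond the scatter), and an 8.2-fold lower number from compound 1 to compound 3 (0.92 log units; beyond the scatter).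

Compound 4 `COc1ccc(C(=O)Nc2ccccn2)cc1OC1CCCC1` has not yet been measured; it differs from compound 3 by pyridin-2-yl in place of 2-hydroxyphenyl on an amide-type nitrogen. All three measured steps concern the same group on the amide-type nitrogen, and each moved this assay beyond the scatter, so a change here can plainly matter. None of them, however, involves a pyridin-2-yl, and they point in both directions, so no direction can be read from them. Compound 4 is accordingly expected to lie near compound 3, with a step of a 1.2-fold higher number from compound 3 to compound 4 (0.06 log units; within the scatter), giving an estimate of 1500 nM, within a wide range from 300 nM to 8000 nM.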

Compound 4, half-maximal inhibitory concentration: 1000 nM
Beside the measured number, compound 4's estimate is 1.5-fold (0.18 log units) above it, and the stated range covers the measured number.
By their numbers in this assay, from the lowest: compound 2; then compounds 4 and 3 (each within the scatter of the next); then compound 1.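

In this assay, pyridin-2-yl and 2-hydroxyphenyl on the amide-type nitrogen cannot be told apart, with a 1.3-fold lower number from compound 3 to compound 4 (0.11 log units; within the scatter), although the entering group has 0 hydrogen-bond donors where the leaving group has 1. Among these compounds, then, a number in this range does not depend on a hydrogen-bond donor in the group on this nitrogen, and a ring nitrogen serves as well as the hydroxy-bearing carbon ring. The other two steps, a 14-fold higher number from compound 2 to compound 4 (1.15 log units; beyond the scatter) and an 11-fold lower number from compound 1 to compound 4 (1.03 log units; beyond the scatter), place pyridin-2-yl in the same middle ground as 2-hydroxyphenyl, clear of both 2,6-difluorophenyl and 2-fluorophenyl.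

Nothing given here bears on the reason for these numbers. Going by these compounds, it remains open whether pyridin-3-yl or 2-methoxyphenyl on the same nitrogen would stay in this middle ground or come nearer to 2,6-difluorophenyl.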